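The source may hold more compounds than are shown below. What is called first, only, known or untested is meant among the compounds shown, and "the series" means these compounds.

Measured so far:
compound 1 `COc1cc(C(N)=O)cc2nc(NC(=O)c3ccccn3)n(CCCNC(=O)OCc3ccccc3)c12` — > 100000 nM
compound 2 `CCn1nccc1C(=O)Nc1nc2cc(C(N)=O)cc(OC)c2n1CCCNC(=O)OCc1ccccc1` — > 100000 nM

In an assay for activation of interferon regulatory factor 3 (Homo sapiens), read by a luciferase reporter, with a stated time of 20 h (on this read-out higher numbers stand for an effect only at larger amounts of compound and lower numbers for an effect already at smaller amounts), compound 1 gives > 100000 nM, which is a limit of the assay rather than a number. In this assay compound 2 likewise gives > 100000 nM, again a limit. The step that the two limits leave unreadable from compound 1 to compound 2 is therefore unreadable in size. Compound 3 `COc1cc(C(N)=O)cc2nc(NC(=O)c3ccnn3C)n(CCCNC(=O)OCc3ccccc3)c12` differs from compound 2 by hydrogen in place of methyl on a saturated chain carbon bound to an aromatic nitrogen. Among the compounds with values here, the one measured step gives no readable size, and both values sit at the same limit (the limit of > 100000 nM in this assay, at which 2 of the 2 values shown sit), so no step beyond the scatter can be predicted in either direction. Compound 3 is expected to give about 150000 nM, within 50000 nM to 500000 nM, most likely again a limit. That estimate implies a step that the limit leaves unreadable from compound 2 to compound 3 from compound 2 to compound 3.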

Compound 3, half-maximal effective concentration: > 100000 nM
Compound 3: only a limit was reported (the forecaster's own chance of this, stated with the estimate: 85%); the middle value lies beyond the limit too.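

The steps among compound 1, compound 2 and compound 3 cannot be read; all three values are limits of the assay. The compounds shown leave open what size, if any, these changes have.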